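A few compounds are considered here, and "the series" means these few. Any claim that something is new, unique, unknown or untested is made for them only; others in the source may bear on it.

Measured compounds:
compound 1 `CN(C)CCCCOc1ccc2oc(-c3ccccc3)cc(=O)c2c1` — 400 nM
compound 2 `O=c1cc(-c2ccccc2)oc2ccc(OCCCCCCN3CCCCC3)cc12` — 54 nM

In an assay on isolated protein (Cavia porcellus) with Sigma non-opioid intracellular receptor 1 (Homo sapiens) as the target, read by radioligand binding (on this read-out lower numbers stand for stronger inhibition and higher numbers for weaker inhibition), compound 2 holds the lowest number of the two; its nearest neighbour is compound 1, and the gap between them, a 7.4-fold lower number from compound 1 to compound 2 (0.87 log units; beyond the scatter), lies beyond the scatter. Compound 3 `CN(CCCCCCOc1ccc2oc(-c3ccccc3)cc(=O)c2c1)Cc1ccccc1` is the next to be measured. It differs from compound 2 in one place: benzyl(methyl)amino in place of piperidin-1-yl on a saturated chain carbon, six bonds along the chain from an oxygen on an aromatic ring. Among the compounds with values here, the only measured step bearing on this position is a 7.4-fold lower number from compound 1 to compound 2 (0.87 log units; beyond the scatter), which also exchanged one amino group for another on a saturated chain carbon and moved the number down by a modest amount. That step concerned a different pair of groups, so it gives no firm direction for the present swap, and the chain length and the shared core are untouched. A step within or near the scatter, a 1.1-fold higher number from compound 2 to compound 3 (0.05 log units; within the scatter), is therefore expected. Compound 3 is estimated at 60 nM in this assay, with a range from 20 nM to 200 nM.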

Compound 3, half-maximal inhibitory concentration: 75 nM
For compound 3 the middle estimate is 1.3-fold (0.10 log units) below the measured one; low and high end bracket the measured number.
By their numbers in this assay, from the lowest: compounds 2 and 3 (each within the scatter of the next); then compound 1.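

In this assay, a 1.4-fold higher number from compound 2 to compound 3 (0.14 log units; within the scatter) does not tell benzyl(methyl)amino apart from piperidin-1-yl at this position, so the end of the chain accepts an open amine bearing an aromatic ring as well as a saturated ring amine. a 5.3-fold lower number from compound 1 to compound 3 (0.73 log units; beyond the scatter) places a second amine on the same side of compound 1 as compound 2, though that step changes the chain and the amino group together. No measurement given here accounts for either step.

The compounds shown leave open whether the distance from compound 1 follows the longer chain or the larger amino group, as neither change is seen alone. From the compounds shown here alone, how a morpholin-4-yl group or a still longer chain would read at this position also remains open.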